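The compounds below may be only part of what the source reports. "The series", "measured", "known", "first", "only" and "open" are said of these compounds alone.

Working notes on the series, read in a functional assay on SW-620 cells (Homo sapiens) for cytotoxicity, read by MTT assay, with a stated time of 72 h; a lower number here means a stronger inhibitor, a higher number a weaker inhibitor. Compound 1 (`COc1ccc(/C=C2\CCC/C(=C\c3ccccc3Cl)C2=O)cc1OC`) gives 7100 nM, compound 2 (`COc1ccc(/C=C2\CCC/C(=C\c3cccc(Br)c3)C2=O)cc1OC`) gives 4200 nM, and compound 3 (`COc1ccc(/C=C2\CCC/C(=C\c3ccc(Br)cc3)C2=O)cc1OC`) gives 5200 nM. Compound 3 lies within the scatter of both others, so the three form one group with no order among them.

The next step leads to compound 4 (`COc1ccc(/C=C2\CCC/C(=C\c3ccc(OC)c(OC)c3)C2=O)cc1`): methoxy in place of bromo on an aromatic carbon. In words, this is methoxy in place of bromo on an aromatic carbon, para to a large group.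

Among the measured compounds shown here, no measured step makes this exact exchange. The nearest evidence is the set of changes among the halogen-bearing rings: a 1.2-fold higher number from compound 2 to compound 3 (0.09 log units; within the scatter), a 1.4-fold lower number from compound 1 to compound 3 (0.14 log units; within the scatter) and a 1.7-fold lower number from compound 1 to compound 2 (0.23 log units; within the scatter), each within the scatter. For the measured compounds named here, no measured compound carries 4-methoxyphenyl in this place, so the evidence is indirect and the range stays wide. No step beyond the scatter is expected, and no direction is favoured. The expected step is a 1.0-fold lower number from compound 3 to compound 4 (0.02 log units; within the scatter). For compound 4 the estimated value is 5000 nM, with an expected range of 2000 nM to 12000 nM.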

Compound 4, half-maximal inhibitory concentration: 6600 nM
Estimate against measurement, compound 4: 1.3-fold (0.12 log units) below, within the range that was stated.
By their numbers in this assay, from the lowest: compounds 2, 3, 4 and 1 (each within the scatter of the next).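

In this assay the exchange of bromo for methoxy, on an aromatic carbon para to a large group, gives a 1.3-fold higher number from compound 3 to compound 4 (0.10 log units; within the scatter), so a group other than a halogen at this place cannot be told apart from the bromo. The wider comparisons agree: a 1.6-fold higher number from compound 2 to compound 4 (0.20 log units; within the scatter) and a 1.1-fold lower number from compound 1 to compound 4 (0.03 log units; within the scatter) keep compound 4 in one group with the three halogen-bearing compounds, and the series still shows no order. Nothing available offers an explanation for why these four compounds stay together.

Still open, on these data alone, is whether any group on this ring can move the number beyond the scatter, for instance an amine or a carboxylic acid. The other side of the core stays the same throughout, so what it contributes cannot be read from these compounds.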